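Compound 4 Tested Against a Shared Core

The source may report more compounds than this note shows. Statements on the series, on what has been measured and on what is new or still open speak of the compounds shown alone.

Compound 3 `Cc1ccccc1-c1ccc(-n2cc(-c3ccccc3)nn2)cc1` belongs to a set of three compounds built on one shared core. In a functional assay on MCF7 cells (Homo sapiens) for inhibition, read by resazurin assay, with a stated time of 72 h (a lower number here means a stronger inhibitor, a higher number a weaker inhibitor), compound 3 gives < 50000 nM, which is a limit of the assay and not a number. Compound 1 `N#Cc1cncc(-c2ccc(-n3cc(-c4ccccc4)nn3)cc2)c1` in this assay gives < 50000 nM, again only a limit. Compound 2 `Clc1ccccc1-c1ccc(-n2cc(-c3ccccc3)nn2)cc1` in this assay gives < 50000 nM, also a limit. Because all three values sit at the same limit (the limit of < 50000 nM in this assay, at which 3 of the 3 values shown sit), none of the three steps between them can be read: a step that the two limits leave unreadable from compound 1 to compound 2, a step that the two limits leave unreadable from compound 1 to compound 3 and a step that the two limits leave unreadable from compound 2 to compound 3 all remain of unreadable size.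

Compound 4 `Fc1ccc(Cl)cc1-c1ccc(-n2cc(-c3ccccc3)nn2)cc1` differs from compound 3 by a single change: 5-chloro-2-fluorophenyl in place of 2-methylphenyl on an aromatic carbon. Among the measured compounds shown here, the steps that bear on this change are those from compound 3 to its two neighbours and the exchange of methyl for chloro between compound 2 and compound 3, yet their sizes are not readable, so nothing in the measured set points in either direction. The expected step is therefore a step that the limit leaves unreadable from compound 3 to compound 4, no step beyond the scatter that can be foreseen. Compound 4 is estimated at 20000 nM, with a range from 3000 nM to 50000 nM, and with a fair chance that this assay again reports only a limit.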

Compound 4, half-maximal inhibitory concentration: < 50000 nM
Compound 4 ended at the assay's limit; the forecaster's own chance of this, stated with the estimate: 70%; the middle value lies beyond the limit too.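

In this assay compound 4 gives < 50000 nM as a limit of the assay and not a number. Its steps to compound 1, compound 2 and compound 3 cannot be read, because the values all stop at one limit: the limit of < 50000 nM in this assay, at which 4 of the 4 values shown sit. The compounds shown leave open whether any of these aromatic groups changes the inhibition at all, and by how much.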